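The compounds below may be only part of what the source reports. "The series", "measured", "known", "first", "only" and "open" are said of these compounds alone.

Measured compounds:
- compound 1, `Cc1cc(C)cc(S(=O)(=O)c2cnc3ccc(F)cc3c2N2CCC(C)CC2)c1`: 83%
- compound 2, `CC1CCN(c2c(S(=O)(=O)c3ccc(C#N)cc3)cnc3c(F)cccc23)CC1`: 86%
- compound 3, `CC1CCN(c2c(S(=O)(=O)c3ccccc3)cnc3cc(F)ccc23)CC1`: 87%

All three were run in an assay on isolated protein for displacement of a labelled ligand from metabotropic glutamate receptor 5 (Homo sapiens), with a stated time of 60 min, tested at 1 uM; a higher number here means more inhibition at the concentration tested (going by the name of the read-out), a lower number less inhibition. Compound 2 gives 86%, a number that falls between the other two; the gap to compound 3 and the gap to compound 1 both lie within the usual scatter, so nothing separates the three on this read-out. The aryl on the sulfonyl varies across the set, from plain phenyl in compound 3 to dimethylphenyl in compound 1 to cyanophenyl in compound 2, and none of these changes moves the read-out beyond the scatter.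

The next compound is compound 4, `COc1ccc(S(=O)(=O)c2cnc3c(F)cccc3c2N2CCC(C)CC2)cc1`, not yet measured in this assay. It differs from compound 2 in one place: methoxy in place of cyano on an aromatic carbon. Taken one bond further out, the change reads as 4-cyanophenyl to 4-methoxyphenyl, with the group sitting para to a large group on the sulfonyl-bearing ring.

Among the measured compounds shown here, no measured step covers this exact exchange, so expectation rests on the three numbers alone. Since variation on this ring leaves compound 1, compound 2 and compound 3 within the scatter of one another, the step of a number 2 percentage points lower from compound 2 to compound 4 (within the scatter) is expected to be no larger than the scatter, in no particular direction. Compound 4 is therefore estimated at 84%, within the range 70% to 94%.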

Compound 4, a percentage reported as inhibition, at one concentration (the size of the read-out at that concentration, not a potency): 67%
Compound 4: middle estimate off by 17 percentage points, on the high side; measured number below the stated range.
By their numbers in this assay, from the lowest: compound 4; then compounds 1, 2 and 3 (each within the scatter of the next).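

In this assay, among the compounds shown here, the exchange of cyano for methoxy on an aromatic carbon gives the only step in this set between compounds that differ in one place: a number 19 percentage points lower from compound 2 to compound 4 (beyond the scatter). The read-out is therefore not indifferent to the group at this place, and 4-cyanophenyl and 4-methoxyphenyl cannot be treated as interchangeable, even though cyano and methoxy have the same heavy-atom and hydrogen-bond acceptor counts. Nothing available explains the step.

On these data alone, it remains open whether the step reflects something particular to methoxy or to cyano, and what an amino, hydroxy or ethoxy group would give at this place. As far as these compounds go, it is also open whether the same exchange would give a step of similar size with the fluorine placed as in compound 1 or compound 3.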